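Swapping trifluoromethyl for chloro on the terminal aryl urea

The compounds below may be only part of what the source reports. "The series", "measured", "known", "first", "only" and "open" are said of these compounds alone.

Three compounds share one core. Compound 1 `COc1cc2cc(Oc3ccc(NC(=O)Nc4ccc(C)cc4)cc3)c(C)nc2cc1OC` gives 85.6% in a functional assay on MDA-MB-231 cells (Homo sapiens) for inhibition, read by sulforhodamine B assay, with a stated time of 48 h, tested at 10 uM (a lower number here means a stronger effect, a higher number a weaker effect of the compound at the concentration tested), compound 2 `COc1cc2cc(Oc3ccc(NC(=O)Nc4ccc(C(F)(F)F)cc4)cc3)c(C)nc2cc1OC` gives 80.9%, and compound 3 `COc1cc2cc(Oc3ccc(NC(=O)Nc4ccc(Cl)c(C(F)(F)F)c4)cc3)c(C)nc2cc1OC` gives -50.6%, the lowest of the three; the step of a number 136.2 percentage points lower from compound 1 to compound 3 (beyond the scatter) and the step of a number 131.5 percentage points lower from compound 2 to compound 3 (beyond the scatter) are both large. Compound 4 `COc1cc2cc(Oc3ccc(NC(=O)Nc4ccc(Cl)c(Cl)c4)cc3)c(C)nc2cc1OC` differs from compound 3 by chloro in place of trifluoromethyl on an aromatic carbon. Going by the values given here, no measured step exchanges these two groups at this place; the only related step, a number 4.7 percentage points lower from compound 1 to compound 2 (within the scatter), exchanges methyl for trifluoromethyl and lies within the scatter. Compound 4 is therefore expected to stay close to compound 3, with a step of a number 15.6 percentage points higher from compound 3 to compound 4 (beyond the scatter) not beyond the scatter. Compound 4 is estimated at -35%, within -85% to 30%.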

Compound 4, a percentage reported as activity, at one concentration (the size of the read-out at that concentration, not a potency): 47.8%
For compound 4 the middle estimate is 82.8 percentage points below the measured one; the whole stated range lies below it.
By their numbers in this assay, from the lowest: compound 3; then compound 4; then compounds 2 and 1 (each within the scatter of the next).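

In this assay, chloro in place of trifluoromethyl on this aromatic carbon gives a number 98.4 percentage points higher from compound 3 to compound 4 (beyond the scatter) and shows directly that the two groups are not interchangeable here. The 3,4-dichlorophenyl group still keeps compound 4 apart from the two compounds with a single substituent, with a number 33.1 percentage points lower from compound 2 to compound 4 (beyond the scatter) and a number 37.8 percentage points lower from compound 1 to compound 4 (beyond the scatter) as the steps to it. Nothing at hand explains the size of these steps. Going by these compounds, it remains open whether bromo, nitrile or methoxy at this place would behave like chloro or like trifluoromethyl, and whether the large step depends on the neighbouring chloro group.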